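Swapping the sulfonamide heteroaryl in a diterpenoid series

The compounds below may be only part of what the source reports. "The series", "measured", "known", "first", "only" and "open" are said of these compounds alone.

Three compounds share one core. Compound 1 `C=C1CC[C@@H]2[C@](C)(COC(C)=O)[C@H](OC(C)=O)CC[C@@]2(C)[C@H]1CC(Nc1ccc(S(=O)(=O)Nc2nccs2)cc1)C1=CCOC1=O` carries a 1,3-thiazol-2-yl group on the sulfonamide nitrogen, compound 2 `C=C1CC[C@@H]2[C@](C)(COC(C)=O)[C@H](OC(C)=O)CC[C@@]2(C)[C@H]1CC(Nc1ccc(S(=O)(=O)Nc2ccc(Cl)nn2)cc1)C1=CCOC1=O` a 6-chloropyridazin-3-yl group, and compound 3 `C=C1CC[C@@H]2[C@](C)(COC(C)=O)[C@H](OC(C)=O)CC[C@@]2(C)[C@H]1CC(Nc1ccc(S(=O)(=O)Nc2ncccn2)cc1)C1=CCOC1=O` a pyrimidin-2-yl group. In a functional assay on ACHN cells (Homo sapiens) for inhibition, read by sulforhodamine B assay, with a stated time of 48 h (on this read-out lower numbers stand for higher toxicity in this test and higher numbers for lower toxicity in this test), compound 1 gives 45000 nM, compound 2 gives 6570 nM and compound 3 gives 6200 nM. Compound 3 therefore sits at the low end of these numbers together with compound 2, the two being within the scatter of each other a 1.1-fold lower number from compound 2 to compound 3 (0.03 log units; within the scatter), while compound 1 stands well apart a 7.3-fold lower number from compound 1 to compound 3 (0.86 log units; beyond the scatter).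

Compound 4 `C=C1CC[C@@H]2[C@](C)(COC(C)=O)[C@H](OC(C)=O)CC[C@@]2(C)[C@H]1CC(Nc1ccc(S(=O)(=O)Nc2cc(C)on2)cc1)C1=CCOC1=O` differs from compound 3 at the same position: 5-methyl-1,2-oxazol-3-yl in place of pyrimidin-2-yl on a sulfonamide nitrogen. Within the data shown here, no measured step exchanges a six-membered ring for another five-membered ring here; the only five-membered example is compound 1, and the steps of a 6.8-fold lower number from compound 1 to compound 2 (0.84 log units; beyond the scatter) and a 7.3-fold lower number from compound 1 to compound 3 (0.86 log units; beyond the scatter) both ran toward lower numbers when the thiazole left. An intermediate outcome is therefore expected, meaning a step of a 2.3-fold higher number from compound 3 to compound 4 (0.35 log units; beyond the scatter) upward in this assay. Compound 4 is estimated at 14000 nM, within 5000 nM to 40000 nM.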

Compound 4, concentration lethal to 50% of the cells: 7050 nM
Beside the measured number, compound 4's estimate is 2.0-fold (0.30 log units) above it, and the stated range covers the measured number.
By their numbers in this assay, from the lowest: compounds 3, 2 and 4 (each within the scatter of the next); then compound 1.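

In this assay, the step of a 1.1-fold higher number from compound 3 to compound 4 (0.06 log units; within the scatter) and the step of a 1.1-fold higher number from compound 2 to compound 4 (0.03 log units; within the scatter) both lie within the scatter, so the 5-methyl-1,2-oxazol-3-yl group on the sulfonamide nitrogen cannot be told apart from the two six-membered aromatic rings. The step of a 6.4-fold lower number from compound 1 to compound 4 (0.81 log units; beyond the scatter) lies beyond the scatter, even though both groups are five-membered aromatic rings, so ring size alone does not separate the numbers at this position. Among these four compounds, only the 1,3-thiazol-2-yl group of compound 1 stands apart, and no supporting data are available to explain this.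

The compounds shown leave open whether the methyl group of compound 4 contributes to its number. They also leave open whether a phenyl ring on the sulfonamide nitrogen would fall with compound 1 or with the other three.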